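The compounds below may be only part of what the source reports. "The series", "measured", "known", "first", "only" and "open" are said of these compounds alone.

Measured so far:
- compound 1 `CC1(C)CCc2cc(C(=O)/C=C/c3ccc(OCc4cn(-c5ccc(Br)cc5)nn4)cc3)c(O)cc2O1`: in a functional assay on IMR-32 cells (Homo sapiens) for antiproliferative activity, read by MTT assay (on this read-out lower numbers stand for stronger inhibition and higher numbers for weaker inhibition), compound 1 gives 69400 nM
- compound 2 `Cc1c(-n2cc(COc3ccc(/C=C/C(=O)c4cc5c(cc4O)OC(C)(C)CC5)cc3)nn2)cccc1[N+](=O)[O-]`: in this assay compound 2 gives "not active" (no number reported)
- compound 3 `COc1ccc(-n2cc(COc3ccc(/C=C/C(=O)c4cc5c(cc4O)OC(C)(C)CC5)cc3)nn2)c([N+](=O)[O-])c1`: in this assay compound 3 gives "not active" (no number reported)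

Compound 3 stands without a number in this assay; its entry reads only as inactive, and compound 2 shares that outcome, so two of the three measured entries carry no value at all. Only compound 1 returns a number, and that number sits far up the scale, so the whole series as seen here is weak. Among the compounds with values here, no step between two measured compounds is available, and nothing about a pattern can be drawn from the three.

The next compound is compound 4 `CC(=O)c1ccc(-n2cc(COc3ccc(/C=C/C(=O)c4cc5c(cc4O)OC(C)(C)CC5)cc3)nn2)cc1`. Its change from compound 3 is 4-acetylphenyl in place of 4-methoxy-2-nitrophenyl on an aromatic nitrogen. With compound 3 giving no number, the size of the step cannot be read from anything measured; the expectation in this assay is for no step beyond the scatter, or for another entry without a number.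

For compound 4 in this assay the estimate is 80000 nM, expected within 30000 nM to 200000 nM, with a substantial chance that only an inactive entry is returned.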

Compound 4, half-maximal inhibitory concentration: "not active" (no number reported)
Compound 4 has no reported number here, and the estimate cannot be compared.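

In this assay compound 3 gives "not active" (no number reported) and compound 4 gives "not active" (no number reported), so no step can be read between them. Nothing measured here bears on why these entries carry no number. The compounds shown leave open whether any group at this place on the shared core gives stronger inhibition than compound 1 at 69400 nM.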